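The source may report more compounds than this note shows. Statements on the series, on what has been measured and on what is new or still open speak of the compounds shown alone.

Compound 1 `CC(C)=CCC/C(C)=C/CC/C(C)=C/CC[C@@H]1[C@@]2(C)CCC(=O)C(C)(C)[C@@H]2CC[C@@]1(C)O` gives 26600 nM in a functional assay on HepG2 cells (Homo sapiens) for cytotoxicity, read by MTT assay, with a stated time of 48 h; a lower number here means a stronger inhibitor, a higher number a weaker inhibitor.
Compound 2 `CC(C)=CCC/C(C)=C/CC/C(C)=C/CC[C@@H]1[C@@]2(C)CC/C(=N\OCc3cn(-c4ccc(Cl)cc4)nn3)C(C)(C)[C@@H]2CC[C@@]1(C)O` gives 19900 nM.
Compound 3 `CC(C)=CCC/C(C)=C/CC/C(C)=C/CC[C@@H]1[C@@]2(C)CC/C(=N\OCc3cn(-c4ccccc4C#N)nn3)C(C)(C)[C@@H]2CC[C@@]1(C)O` gives 21900 nM.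

Compound 3 holds the second highest of the three numbers, but its gap to compound 2 and its gap to compound 1 both lie within the usual scatter, so the three compounds cannot be told apart on these values. Within the data shown here, the one measured step that touches the aryl group on the aromatic nitrogen, a 1.1-fold higher number from compound 2 to compound 3 (0.04 log units; within the scatter), likewise stays within the scatter.

Compound 4 `COc1cc(OC)c(-n2cc(CO/N=C3\CC[C@]4(C)[C@@H](CC/C=C(\C)CC/C=C(\C)CCC=C(C)C)[C@](C)(O)CC[C@H]4C3(C)C)nn2)c(OC)c1` is not yet measured. It differs from compound 3 in one place: 2,4,6-trimethoxyphenyl in place of 2-cyanophenyl on an aromatic nitrogen. Among the measured compounds shown here, the only measured step that bears on this change is the swap of one aryl group for another at the same position, from compound 2 to compound 3, and that step was within the scatter. For the measured compounds named here, nothing among the measured compounds shows that the aryl group on the aromatic nitrogen moves the number in this assay beyond the scatter, so the expectation is a step of about a 1.0-fold higher number from compound 3 to compound 4 (0.00 log units; within the scatter), that is, no change beyond the scatter. Compound 4 is therefore estimated at 22000 nM, with a range from 11000 nM to 44000 nM.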

Compound 4, half-maximal inhibitory concentration: 14100 nM
Beside the measured number, compound 4's estimate is 1.6-fold (0.19 log units) above it; low and high end bracket the measured number.
By their numbers in this assay, from the lowest: compounds 4, 2, 3 and 1 (each within the scatter of the next).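

In this assay, the swap to 2,4,6-trimethoxyphenyl on the aromatic nitrogen gives a 1.6-fold lower number from compound 3 to compound 4 (0.19 log units; within the scatter) and, set against the 4-chlorophenyl group, a 1.4-fold lower number from compound 2 to compound 4 (0.15 log units; within the scatter) as a second step that also stays within the scatter. Among these compounds, the earlier compounds offered only one swap at this position, so a single pair of aryl groups stood behind the reading; three aryl groups now stand behind it, and no step among them leaves the scatter. That holds even though the entering group is larger than the 2-cyanophenyl it replaces and brings in oxygen while the nitrile leaves, so among these compounds neither the nitrile, the chlorine nor the methoxy groups separate one compound from another in this cell assay.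

The compounds shown leave open whether anything at this position can move the number beyond the scatter, for instance a primary amine or a carboxylic acid on the phenyl ring, or a longer alkyl chain in place of the ring. They also leave open whether a phenyl ring with no substituent at all would read the same, and no measurement offered here speaks to why these numbers fall as they do.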